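Sec-butyl to isopropyl on the shared core

The source may hold more compounds than are shown below. What is called first, only, known or untested is meant among the compounds shown, and "the series" means these compounds.

Measured so far:
compound 1 `CCC(C)n1cnc2c(NCc3ccc(C(=O)Nc4ccccc4N)cc3)nc(Cl)nc21` — 67.7%
compound 2 `Nc1ccccc1NC(=O)c1ccc(Cn2cnc3c(Nc4ccccc4)nc(Cl)nc32)cc1` — 77.8%
compound 3 `CC(C)n1cnc2c(Nc3cccc(Cl)c3)nc(NCOCc3ccc(C(=O)Nc4ccccc4N)cc3)nc21` — 43.2%

In a functional assay on NCI-H460 cells (Homo sapiens) for antiproliferative activity, read by CCK-8 assay, with a stated time of 72 h, tested at 8 uM (a higher number here means a stronger effect of the compound at the concentration tested, a lower number a weaker effect), compound 1 gives 67.7%, the second highest of the three numbers. Compound 2 gives 77.8%, which sits higher by a margin beyond the usual scatter, while compound 3 gives 43.2%, lower by a margin that is also beyond the scatter. No pair among these three differs in only one place, so no single-point step between measured compounds is available, and the ranking says nothing about which part of the structure drives the difference.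

Compound 4 `CC(C)n1cnc2c(NCc3ccc(C(=O)Nc4ccccc4N)cc3)nc(Cl)nc21` has not been measured in this assay. Relative to compound 1 the change is hydrogen in place of methyl on a saturated chain carbon, two bonds along the chain from an aromatic nitrogen. The rest of the molecule, including the chloro substituent, the benzylamine link and the aminophenyl amide, is unchanged.

The change removes one carbon from a short saturated chain and nothing else. With no shown step of this kind in the series, the expected step from compound 1 to compound 4 is estimated as small, a number 2.7 percentage points lower from compound 1 to compound 4 (within the scatter), most likely none beyond the scatter. For compound 4 in this assay the value is therefore expected at 65%, with a range from 50% to 78%.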

Compound 4, a percentage reported as inhibition, at one concentration (the size of the read-out at that concentration, not a potency): 80.5%
Beside the measured number, compound 4's estimate is 15.5 percentage points below it; the whole stated range lies below it.
By their numbers in this assay, from the lowest: compound 3; then compound 1; then compounds 2 and 4 (each within the scatter of the next).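

In this assay sec-butyl to isopropyl, a change that removes one carbon and no hydrogen-bond donor or acceptor, gives a number 12.8 percentage points higher from compound 1 to compound 4 (beyond the scatter) with the chloro substituent, the benzylamine link and the aminophenyl amide left as they were. Within the data shown here, this is the first single-point step, and it shows that the read-out at this one concentration responds to a small trim of this saturated chain, something the earlier compounds, with no pair differing in only one place, could not show. Nothing available accounts for the size or direction of this step, so it stands as an observation only.

As far as these compounds go, with just these two chains compared at this position, no trend with chain size can be drawn, and it remains open whether an ethyl, a methyl, a cyclopropyl or a longer chain such as n-pentyl would extend, hold or reverse the step. From the compounds shown here alone, it is also open whether sec-butyl to isopropyl gives a step of similar size when the benzylamine link is replaced by an aniline or when the chloro substituent is replaced by an amine.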